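Acylhydrazino purine ribosides: a furan to isoxazole swap

The source may report more compounds than this note shows. Statements on the series, on what has been measured and on what is new or still open speak of the compounds shown alone.

Compound 1 `CCNC(=O)[C@H]1O[C@@H](n2cnc3c(NNC(=O)c4ccc(Cl)cc4)ncnc32)[C@H](O)[C@@H]1O` gives > 5000 nM in an assay on CHO cells for displacement of a labelled ligand from adenosine receptor A3 (Homo sapiens); on this read-out lower numbers stand for stronger inhibition and higher numbers for weaker inhibition.
Compound 2 `CCNC(=O)[C@H]1O[C@@H](n2cnc3c(NNC(=O)c4cccnc4)ncnc32)[C@H](O)[C@@H]1O` gives > 5000 nM in this assay.
Compound 3 `CCNC(=O)[C@H]1O[C@@H](n2cnc3c(NNC(=O)c4ccco4)nc(Cl)nc32)[C@H](O)[C@@H]1O` gives > 5000 nM in this assay.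

Each of these three values is a limit of this assay rather than a number. Compound 1 sits at the limit > 5000 nM. Compound 2 also sits at the limit > 5000 nM, so the step that the two limits leave unreadable from compound 1 to compound 2 cannot be read. Compound 3, with its limit > 5000 nM, therefore stands where every measured compound stands: the limit of > 5000 nM in this assay, at which 3 of the 3 values shown sit, describes the whole series.

Compound 4 `CCNC(=O)[C@H]1O[C@@H](n2cnc3c(NNC(=O)c4cc(C)on4)nc(Cl)nc32)[C@H](O)[C@@H]1O` differs from compound 3 by 5-methyl-1,2-oxazol-3-yl in place of furan-2-yl on a carbonyl carbon. Among the measured compounds shown here, no measured step bears on this change: the one step in hand, a step that the two limits leave unreadable from compound 1 to compound 2, concerns a different acyl group and is itself unreadable. With nothing to point the other way, compound 4 is expected to remain near the limit, and the step that the limit leaves unreadable from compound 3 to compound 4 is estimated as none beyond the scatter. For compound 4 the estimate in this assay is 8000 nM, within a range from 2500 nM to 30000 nM.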

Compound 4, inhibition constant: > 5000 nM
Compound 4: no number, only a limit (the forecaster's own chance of this, stated with the estimate: 80%); the middle value lies beyond the limit too.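

In this assay compound 4 gives > 5000 nM, a limit and not a number. Compound 3 also stands at a limit, so no step can be read between compound 3 and compound 4. The compounds shown leave open whether any change of acyl group alters the inhibition, because the whole series stays at one limit: the limit of > 5000 nM in this assay, at which 4 of the 4 values shown sit.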